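Benzylamide series: sulfinyl to trifluoromethylsulfanyl exchange

This account rests on a few compounds, and the source may have more. Where it says the series, first, only, none or still open, it means among the compounds named here.

Working notes on the benzylamide set. In an assay on HeLa cells with Bile acid receptor (Homo sapiens) as the target, read by a luciferase reporter, with a stated time of 24 h (on this read-out higher numbers stand for an effect only at larger amounts of compound and lower numbers for an effect already at smaller amounts), compound 1 `C[S+]([O-])c1ccc(CNC(=O)c2ccc(C(C)(C)C)cc2)cc1` gives 1300 nM, the highest of the three numbers in hand. Compound 2 `CC(C)(C)c1ccc(C(=O)NCc2ccc(N)cc2Cl)cc1` gives 46 nM in this assay, and compound 3 `CC(NC(=O)c1ccc(C(C)(C)C)cc1)c1ccc(C(=O)O)cc1` gives 76 nM; both sit below compound 1 by margins beyond the scatter, so compound 1 is the weakest of the three measured compounds.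

Compound 4 `CC(C)(C)c1ccc(C(=O)NCc2ccc(SC(F)(F)F)cc2)cc1` is still to be measured. It differs from compound 1 by a group of 5 heavy atoms (1 carbon, 3 fluorine, 1 sulfur; no ring) in place of a group of 3 heavy atoms (1 carbon, 1 oxygen, 1 sulfur; no ring), on an aromatic carbon, in words a group of 5 heavy atoms (1 carbon, 3 fluorine, 1 sulfur; no ring) in place of a group of 3 heavy atoms (1 carbon, 1 oxygen, 1 sulfur; no ring), on an aromatic carbon, para to a large group. Within the data shown here, no measured pair shows this exchange; compounds 2 and 3 are changed in other places, so nothing in hand fixes the size of the step. The expectation is a lower number, beyond the scatter, with the step from compound 1 to compound 4 estimated at a 4.3-fold lower number from compound 1 to compound 4 (0.64 log units; beyond the scatter). Compound 4 is accordingly estimated at 300 nM in this assay, with a range from 80 nM to 1200 nM.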

Compound 4, half-maximal effective concentration: 0.4 nM
Compound 4: middle estimate off by 750-fold (2.88 log units), on the high side; the whole stated range lies above it.
By their numbers in this assay, from the lowest: compound 4; then compounds 2 and 3 (each within the scatter of the next); then compound 1.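

The exchange to (trifluoromethyl)sulfanyl on an aromatic carbon, para to a large group, gives in this assay a 3300-fold lower number from compound 1 to compound 4 (3.51 log units; beyond the scatter) and shows that a change at this one position on the shared core can produce a large step. This exchange leaves the printed hydrogen-bond donor and acceptor counts and the net charge unchanged, so those counts do not distinguish the two groups. Nothing available on these compounds accounts for the size of the step.

Open, on these data alone, is how much of the step depends on the sulfur and how much on the trifluoromethyl group; a methylsulfanyl group, a trifluoromethyl group directly on the ring, or a trifluoromethoxy group at this position would help separate them. Also open, as far as these compounds go, is whether (trifluoromethyl)sulfanyl gives a similar step on the cores of compound 2 and compound 3.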